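The source may hold more compounds than are shown below. What is called first, only, known or untested is meant among the compounds shown, and "the series" means these compounds.

For the measured compounds named here, compound 3, `O=c1[nH]/c(=N\OCCCc2ccc([N+](=O)[O-])cc2)ccn1[C@@H]1O[C@H](COP(=O)(O)OP(=O)(O)OP(=O)(O)O)[C@@H](O)[C@H]1O`, is the compound with the lowest number among the three measured so far: in a functional assay on 1321-N1 cells for agonist activity at P2Y purinoceptor 4 (Homo sapiens), read by scintillation counting and inositol phosphate accumulation (a lower number here means that less compound is needed, a higher number that more compound is needed for the effect), compound 3 gives 84 nM. The nearest of the others is compound 2, `O=c1[nH]/c(=N\OCCCc2cccc([N+](=O)[O-])c2)ccn1[C@@H]1O[C@H](COP(=O)(O)OP(=O)(O)OP(=O)(O)O)[C@@H](O)[C@H]1O`, which in this assay gives 95 nM; the furthest is compound 1, `O=c1[nH]/c(=N\OCCCc2ccc(Br)cc2)ccn1[C@@H]1O[C@H](COP(=O)(O)OP(=O)(O)OP(=O)(O)O)[C@@H](O)[C@H]1O`, which gives 141 nM. None of these three stands apart from the others, since every step among them lies within the scatter: a 1.5-fold lower number from compound 1 to compound 2 (0.17 log units; within the scatter), a 1.7-fold lower number from compound 1 to compound 3 (0.22 log units; within the scatter) and a 1.1-fold lower number from compound 2 to compound 3 (0.05 log units; within the scatter).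

Compound 4, `O=c1[nH]/c(=N\OCCCc2cccnc2)ccn1[C@@H]1O[C@H](COP(=O)(O)OP(=O)(O)OP(=O)(O)O)[C@@H](O)[C@H]1O`, differs from compound 3 in one place: pyridin-3-yl in place of 4-nitrophenyl on a saturated chain carbon, three bonds along the chain from an oxygen. Going by the values given here, no measured step covers an exchange of the aromatic ring itself. The three measured steps only show that changing the group on the ring, or moving it, left this assay unmoved beyond the scatter, which bears on the present change only loosely, as the ring loses its nitro group while gaining a ring nitrogen. The account therefore expects a step of uncertain direction and modest size for compound 4, a 2.4-fold higher number from compound 3 to compound 4 (0.38 log units; beyond the scatter), with a slight lean toward a higher number. Compound 4 is estimated to give 200 nM in this assay, with a range from 60 nM to 700 nM.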

Compound 4, half-maximal effective concentration: 300 nM
Beside the measured number, compound 4's estimate is 1.5-fold (0.18 log units) below it; low and high end bracket the measured number.
By their numbers in this assay, from the lowest: compounds 3, 2 and 1 (each within the scatter of the next); then compound 4.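

At this position, on a saturated chain carbon three bonds along the chain from an oxygen, exchanging the aromatic ring itself moves the number in this assay beyond the scatter, which no change among the substituted phenyl groups had done. Pyridin-3-yl gives a modest rise in the number against each of them: against 4-nitrophenyl (a 3.6-fold higher number from compound 3 to compound 4 (0.55 log units; beyond the scatter)), against 3-nitrophenyl (a 3.2-fold higher number from compound 2 to compound 4 (0.50 log units; beyond the scatter)) and against 4-bromophenyl (a 2.1-fold higher number from compound 1 to compound 4 (0.33 log units; beyond the scatter)), so compound 4 stands apart from the other three, which remain within the scatter of one another. Nothing available accounts for this rise.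

The change removes the substituent from the ring and brings in a ring nitrogen at the same time, so the compounds shown do not separate these two parts of the exchange, and an unsubstituted phenyl on the same chain would be the direct test. Also open, as far as these compounds go, is how the other pyridine isomers, pyridin-2-yl and pyridin-4-yl, a carboxylic acid or an amine on the phenyl ring, or a longer chain would read in this assay.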